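This account rests on a few compounds, and the source may have more. Where it says the series, first, only, none or still open, it means among the compounds named here.

Series notes. Compound 1 `Cn1nnnc1SCC(=O)N/N=c1/scc(-c2ccc(Br)cc2)n1-c1ccccc1` gives 19.3 ug/mL in an ADME assay on NIH3T3 cells (Mus musculus) for cytotoxicity, read by MTT assay, with a stated time of 24 h (a higher number here means a weaker inhibitor, a lower number a stronger inhibitor), the lowest of the three numbers recorded so far. Compound 2 `Cn1cnnc1SCC(=O)N/N=c1/scc(-c2ccc(Br)cc2)n1-c1ccccc1` gives 58.3 ug/mL in this assay, and compound 3 `O=C(CSc1ncccn1)N/N=c1/scc(-c2ccc(Br)cc2)n1-c1ccccc1` gives 273 ug/mL in this assay. Every measured step alters the heteroaryl on the sulfur: a 3.0-fold higher number from compound 1 to compound 2 (0.48 log units; beyond the scatter) and a 14-fold higher number from compound 1 to compound 3 (1.15 log units; beyond the scatter), with a 4.7-fold higher number from compound 2 to compound 3 (0.67 log units; beyond the scatter) between them. Compound 4 `Cn1nnnc1SCC(=O)N/N=c1/scc(-c2ccc(Cl)cc2)n1-c1ccccc1` is not yet measured; it differs from compound 1 by chloro in place of bromo on an aromatic carbon. For the measured compounds named here, no measured step touches the bromo group, so none bears directly on this change, and a step in this assay of no more than the scatter is expected, in no fixed direction. Compound 4 is therefore expected to give 21 ug/mL in this assay, with a range of 9 ug/mL to 48 ug/mL, meaning a 1.1-fold higher number from compound 1 to compound 4 (0.04 log units; within the scatter).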

Compound 4, half-maximal inhibitory concentration: 40 ug/mL
For compound 4 the middle estimate is 1.9-fold (0.28 log units) below the measured one; the range from low to high includes it.
By their numbers in this assay, from the lowest: compound 1; then compounds 4 and 2 (each within the scatter of the next); then compound 3.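

For the compounds shown here, this is the only measured step away from the heteroaryl on the sulfur, and it shows that the aryl halogen also matters in this assay: the change from 4-bromophenyl to 4-chlorophenyl gives a 2.1-fold higher number from compound 1 to compound 4 (0.32 log units; beyond the scatter) with the 1-methyl-1H-tetrazol-5-yl group held fixed. No measured evidence explains this step. Still open, on these data alone, is whether the same halogen change gives a similar step with the pyrimidin-2-yl group on the sulfur, and how an amine or a methoxy group at this position would read.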